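This account rests on a few compounds, and the source may have more. Where it says the series, first, only, none or still open, it means among the compounds named here.

Of the compounds shown here, three with a shared core have been measured in a functional assay on cells for antagonist activity at Free fatty acid receptor 1 (Homo sapiens), read by TR-FRET and inositol phosphate accumulation, with a stated time of 2 h; on this read-out lower numbers stand for stronger inhibition and higher numbers for weaker inhibition. Compound 1, `Cc1cc(COc2ccccc2)nc(-c2ccccn2)n1`, carries an unsubstituted phenyl ring and in this assay compound 1 gives 794 nM. Compound 2, `Cc1cc(COc2ccccc2Cl)nc(-c2ccccn2)n1`, adds a chloro group and in this assay compound 2 gives 316 nM; that is a 2.5-fold lower number from compound 1 to compound 2 (0.40 log units; beyond the scatter). Compound 3, `CC(=O)Nc1ccc(OCc2cc(C)nc(-c3ccccn3)n2)cc1`, carries an acetamido group instead. In this assay compound 3 gives > 39800 nM, which is a limit of the assay and not a number. Compound 3 therefore stands at the weak end of the three, at the limit of > 39800 nM in this assay, at which 1 of the 3 values shown sits, and the change from compound 1 was an at least 50-fold higher number from compound 1 to compound 3 (1.70 log units; beyond the scatter).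

Compound 4, `Cc1cc(COc2ccc(F)cc2)nc(-c2ccccn2)n1`, is the next step: fluoro in place of acetamido on an aromatic carbon. The acetamido group that accompanied the large loss from compound 1 to compound 3 is removed, and a single halogen takes its place, as a chloro did in the modest gain from compound 1 to compound 2. The step from compound 3 to compound 4 is therefore expected to be a large drop in the number, an at least 56-fold lower number from compound 3 to compound 4 (1.75 log units; beyond the scatter), back near where compound 1 stands. Compound 4 is estimated at 700 nM in this assay, with a range from 200 nM to 3000 nM.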

Compound 4, half-maximal inhibitory concentration: 631 nM
Beside the measured number, compound 4's estimate is 1.1-fold (0.05 log units) above it, within the range that was stated.
By their numbers in this assay, from the lowest: compounds 2, 4 and 1 (each within the scatter of the next, the first and the last beyond it). At a limit, above all of these: compound 3.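

With fluoro on this aromatic carbon, para to a large group, the number in this assay cannot be told apart from that of the unsubstituted compound (a 1.3-fold lower number from compound 1 to compound 4 (0.10 log units; within the scatter)) or from that of the chloro compound, whose halogen sits elsewhere on the ring (a 2.0-fold higher number from compound 2 to compound 4 (0.30 log units; within the scatter)). A group on this carbon therefore does not by itself go with a loss, as swapping acetamido for fluoro at the same place shows (an at least 63-fold lower number from compound 3 to compound 4 (1.79 log units; beyond the scatter)). From the compounds shown here alone, the value of compound 3 is a limit of the assay and not a number, so the true size of that step stays unknown: the limit of > 39800 nM in this assay, at which 1 of the 4 values shown sits.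

Going by these compounds, it remains open which part of the acetamido group goes with the loss; a methoxy group or an amine on this carbon would help to separate them. Also open, on these data alone, is how a chloro group would read on this same carbon.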